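A few compounds are considered here, and "the series" means these few. Any claim that something is new, unique, unknown or untested is made for them only; others in the source may bear on it.

These four compounds share one core, a hydroxamic acid carried on a chain attached to a ring that also holds an amide-type nitrogen, and they differ only in the group fixed to that nitrogen. Compound 1 `O=C(CCC1=CCCN(CCCCc2ccc(-c3ccccc3)cc2)C1=O)NO` carries a four-carbon chain ending in a biphenyl group, and in a functional assay on NUGC-3 cells (Homo sapiens) for inhibition, read by sulforhodamine B assay (a higher number here means a weaker inhibitor of growth, a lower number a stronger inhibitor of growth), compound 1 gives 4200 nM. Compound 3 `O=C(CCC1=CCCN(CCCc2ccc3ccccc3c2)C1=O)NO` carries a three-carbon chain ending in a naphthalene group, and in this assay compound 3 gives 790 nM. Compound 2 `CC(=O)Nc1ccc(CN2CCC=C(CCC(=O)NO)C2=O)cc1` carries a benzyl group bearing an acetamido group; in this assay compound 2 gives "not determined" (no result reported), so it stands without a number of its own. Compound 4 `O=C(CCC1=CCCN(Cc2ccc(NC(=O)c3ccccc3)cc2)C1=O)NO` is compound 2 with one change: phenyl in place of methyl on a carbonyl carbon. Within the data shown here, with no measured pair to show what this change does, and no number for compound 2, the step cannot be sized. Compound 4 is expected to land among the values of compound 1 and compound 3, near 1500 nM, in a range from 300 nM to 8000 nM.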

Compound 4, concentration for 50% growth inhibition: > 10000 nM
Compound 4: only a limit was reported; the forecaster's own chance of this, stated with the estimate: 10%; middle value at least 6.6-fold (0.82 log units) from the limit.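

Among these compounds, compound 2 has no number in this assay and compound 4 has only a limit, > 10000 nM in this case, so no step between the two can be read. As far as these compounds go, what benzamido in place of acetamido does to growth inhibition remains open.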